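Branching the alkoxy chain: compound 3 to compound 4

A few compounds are considered here, and "the series" means these few. Any claim that something is new, unique, unknown or untested is made for them only; others in the source may bear on it.

For the measured compounds named here, in a functional assay on J774.A1 cells (Mus musculus) for inhibition, read by immunoassay, with a stated time of 12 h, tested at 30 uM (on this read-out higher numbers stand for more inhibition at the one concentration tested (going by the name of the read-out) and lower numbers for less inhibition), compound 3 `CCCCOc1ccccc1C1CC(=O)c2ccccc2O1` gives 42.5%, the second highest of the three numbers measured so far. Compound 1 `O=C1CC(c2ccccc2OCc2cccc(F)c2)Oc2ccccc21` gives 92.7% and compound 2 `COCOc1ccccc1C1CC(=O)c2ccccc2O1` gives 33.3%. The steps of a number 59.4 percentage points lower from compound 1 to compound 2 (beyond the scatter) and a number 50.2 percentage points lower from compound 1 to compound 3 (beyond the scatter) are both large, whereas a number 9.2 percentage points higher from compound 2 to compound 3 (within the scatter) lies within the scatter. Compound 4 `CC(C)CCOc1ccccc1C1CC(=O)c2ccccc2O1` differs from compound 3 by methyl in place of hydrogen on a saturated chain carbon bound to two saturated chain carbons. Going by the values given here, no measured step alters the chain itself; the one step that exchanges one alkoxy group for another, a number 9.2 percentage points higher from compound 2 to compound 3 (within the scatter), stayed within the scatter, so in this assay a step no larger than the scatter is expected, in either direction. Compound 4 is therefore estimated at 45%, range 25% to 65%, an expected step of a number 2.5 percentage points higher from compound 3 to compound 4 (within the scatter).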

Compound 4, a percentage reported as inhibition, at one concentration (the size of the read-out at that concentration, not a potency): 43.6%
Beside the measured number, compound 4's estimate is 1.4 percentage points above it, within the range that was stated.
By their numbers in this assay, from the lowest: compounds 2, 3 and 4 (each within the scatter of the next, the first and the last beyond it); then compound 1.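

In this assay, methyl on a saturated chain carbon bound to two saturated chain carbons leaves the read-out essentially unchanged, with a number 1.1 percentage points higher from compound 3 to compound 4 (within the scatter). Isobutyl in place of methoxy gives a number 10.3 percentage points higher from compound 2 to compound 4 (beyond the scatter), a modest step, whereas isobutyl in place of 3-fluorophenyl gives a number 49.1 percentage points lower from compound 1 to compound 4 (beyond the scatter), so branching does not close the gap to compound 1. No measurement available here accounts for these steps. Still open, going by these compounds, is how a longer chain, or an amine or carboxylic acid at the chain end, would read, and whether plain phenyl would match 3-fluorophenyl.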